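A few compounds are considered here, and "the series" means these few. Any claim that something is new, unique, unknown or untested is made for them only; others in the source may bear on it.

Compound 1 `CCOC(=O)c1cccc(-c2ccc(OCC)cc2)c1` gives 50000 nM in an assay on COS-7 cells for inhibition of patatin-like phospholipase domain-containing protein 2 (Mus musculus); on this read-out lower numbers stand for stronger inhibition and higher numbers for weaker inhibition. Compound 2 `CCOc1ccc(-c2cccc(S(=O)(=O)N(C)C)c2)cc1` gives 110000 nM in this assay, which is a 2.2-fold higher number from compound 1 to compound 2 (0.34 log units; beyond the scatter). Compound 3 `CCCCCCOC(=O)c1cccc(-c2ccc(OCC)cc2)c1` sits at the limit of > 200000 nM in this assay, at which 1 of the 3 values shown sits, that is > 200000 nM, a limit of the assay and not a number. The change to compound 4 `CCOc1ccc(-c2cccc(C(=O)OCCOC)c2)cc1` is methoxy in place of butyl on a saturated chain carbon, two bonds along the chain from an oxygen next to a carbonyl group. The measured step that bears on it is an at least 4.0-fold higher number from compound 1 to compound 3 (0.60 log units; beyond the scatter), where the butyl entered on this chain carbon; the step with the dimethylsulfamoyl lies elsewhere and says little here. Since compound 4 loses that butyl, it is expected to return toward the level of compound 1. Compound 4 is therefore estimated at 70000 nM, between 25000 nM and 200000 nM, which is expected to mean an at least 2.8-fold lower number from compound 3 to compound 4 (0.45 log units; beyond the scatter).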

Compound 4, half-maximal inhibitory concentration: 70000 nM
For compound 4 middle estimate and measured number coincide at the digits printed, within the range that was stated.
By their numbers in this assay, from the lowest: compounds 1, 4 and 2 (each within the scatter of the next, the first and the last beyond it). At a limit, above all of these: compound 3.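

At this chain carbon in this assay the outcome depends on the group: methoxy in place of butyl gives an at least 2.8-fold lower number from compound 3 to compound 4 (0.45 log units; beyond the scatter) while methoxy in place of hydrogen gives a 1.4-fold higher number from compound 1 to compound 4 (0.15 log units; within the scatter) and so stays level with compound 1. On the aromatic carbon, (2-methoxyethoxy)carbonyl in place of dimethylsulfamoyl gives a 1.6-fold lower number from compound 2 to compound 4 (0.20 log units; within the scatter) and does not separate the two groups. Compound 3 remains a limit of the assay and not a number: the limit of > 200000 nM in this assay, at which 1 of the 4 values shown sits. The compounds shown leave open whether an amine or a carboxylic acid on this chain carbon would read like methoxy or like butyl, and whether any group here gives a lower number than compound 1.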